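The compounds below may be only part of what the source reports. "The series", "measured", "known", "first", "only" and "open" are said of these compounds alone.

Measured so far:
- compound 1 `COc1ccc(CNc2nc([SeH])nc3ccccc23)cc1` — 42700 nM
- compound 2 `CCCCC[Se]c1nc(NCc2ccc(SC)cc2)c2ccccc2n1` — 34700 nM

In a functional assay on MCF7 cells (Homo sapiens) for cytotoxicity, read by MTT assay, with a stated time of 72 h (a lower number here means a stronger inhibitor of growth, a higher number a weaker inhibitor of growth), compound 2 gives 34700 nM and compound 1 gives 42700 nM; the two numbers lie within the scatter of each other, so neither stands apart.

Compound 3 `CSc1ccc(CNc2nc([SeH])nc3ccccc23)cc1` is not yet measured. It differs from compound 2 in one place: hydrogen in place of pentyl on a selenium. Among the measured compounds shown here, no measured pair shows this change directly. Since compound 1, which also carries hydrogen on selenium, and compound 2 sit within the scatter of each other, the step of a 1.2-fold higher number from compound 2 to compound 3 (0.06 log units; within the scatter) is expected to stay within the scatter, in no clear direction. For compound 3 the expected value is 40000 nM, with a range from 15000 nM to 100000 nM.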

Compound 3, concentration for 50% growth inhibition: 48100 nM
Compound 3: middle estimate off by 1.2-fold (0.08 log units), on the low side, within the range that was stated.
By their numbers in this assay, from the lowest: compounds 2, 1 and 3 (each within the scatter of the next).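

In this assay, among the compounds shown here, hydrogen in place of pentyl on a selenium gives a 1.4-fold higher number from compound 2 to compound 3 (0.14 log units; within the scatter), the first direct reading of this change, and the pentyl group does not separate the two compounds. Methylsulfanyl in place of methoxy on an aromatic carbon gives a 1.1-fold higher number from compound 1 to compound 3 (0.05 log units; within the scatter), so this swap, read with hydrogen on the selenium, does not separate them either. Nothing available explains either step.

Open, on these data alone, is whether a longer chain on the selenium, or an amine at the end of that chain, would give a step beyond the scatter. Also open, as far as these compounds go, is how a carboxylic acid in place of methylsulfanyl on the aromatic carbon would read.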